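Swapping a Formyl for an Ethynyl on a Weak Cytotoxic Scaffold

A few compounds are considered here, and "the series" means these few. Any claim that something is new, unique, unknown or untested is made for them only; others in the source may bear on it.

Three related compounds have been tested in a functional assay on A549 cells (Homo sapiens) for cytotoxicity, read by MTT assay, with a stated time of 48 h; a lower number here means a stronger inhibitor, a higher number a weaker inhibitor. Compound 1, with the structure `C=C1CC[C@@H](C(C)C)[C@]12CC=C(C=O)CC2`, gives 170000 nM. Compound 2, `CC1(C)CCCC2=CC=C(C=O)CC[C@]21C`, gives 138000 nM, and compound 3, `CC1(C)CCC[C@]1(C)c1ccc(C=O)cc1`, gives 217000 nM. Compound 1 thus holds the second highest of the three numbers, yet its gaps to compound 2 and to compound 3 both fall within the usual scatter, so all three read as comparably weak inhibitors of cell growth.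

The new compound 4, `C#CC1=CC[C@]2(CC1)C(=C)CC[C@H]2C(C)C`, differs from compound 1 in one place: ethynyl in place of formyl on a double-bonded ring carbon. Going by the values given here, nothing measured so far tracks this change, since no pair of tested compounds differs in just this way, and the three known values are all close together.

With that thin basis, the step from compound 1 to compound 4 is expected to be small, a 1.2-fold higher number from compound 1 to compound 4 (0.07 log units; within the scatter), not clearly beyond the scatter in either direction. Compound 4 is therefore estimated at 200000 nM, with a plausible range from 80000 nM to 500000 nM.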

Compound 4, half-maximal inhibitory concentration: 103000 nM
Compound 4: middle estimate off by 1.9-fold (0.29 log units), on the high side; low and high end bracket the measured number.
By their numbers in this assay, from the lowest: compounds 4, 2, 1 and 3 (each within the scatter of the next, the first and the last beyond it).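

In this assay, ethynyl in place of formyl on a double-bonded ring carbon gives a 1.7-fold lower number from compound 1 to compound 4 (0.22 log units; within the scatter). Going by these compounds alone, this is the first direct test of this position, and it shows that the formyl, with its one hydrogen-bond acceptor, can give way to an ethynyl, with none, without a step beyond the scatter. Nothing available explains how these two groups come to read alike, so the result describes the exchange without accounting for it.

The compounds shown leave open whether a group of another kind at this position, such as an amine or a carboxylic acid, would give a step beyond the scatter. They also leave open whether the same exchange would read alike on the cores of compound 2 and compound 3.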